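Amide for Benzyl Ester in a Purine Tail Flick Series

The source may report more compounds than this note shows. Statements on the series, on what has been measured and on what is new or still open speak of the compounds shown alone.

Of the compounds shown here, three have been tested in a functional assay on the whole organism (Tail, strain ICR) with Mus musculus as the target, in the tail flick test, with a stated time of 90 min, at a dose of 25 umol/kg by the oral route; a higher number here means a stronger effect of the compound at the dose given, a lower number a weaker effect. Compound 1 `O=C(CN(c1nc(Cl)nc2[nH]cnc12)C1CC1)N[C@@H](CC(=O)OCc1ccccc1)C(=O)OCc1ccccc1` gives 15.6% and stands lowest of the three; compound 2 `O=C(CN(c1ncnc2c1ncn2C1CCCCO1)C1CC1)N[C@@H](CO)C(=O)OCc1ccccc1` gives 32.2% and compound 3 `NC(=O)C[C@H](NC(=O)CN(c1ncnc2c1ncn2C1CCCCO1)C1CC1)C(=O)OCc1ccccc1` gives 35%, both beyond the scatter above compound 1. Going by the values given here, the only single change measured so far, a number 2.8 percentage points higher from compound 2 to compound 3 (within the scatter), concerns a different position and lies within the scatter.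

Compound 4 `NC(=O)C[C@H](NC(=O)CN(c1nc(Cl)nc2[nH]cnc12)C1CC1)C(=O)OCc1ccccc1` is compound 1 with one change: amino in place of benzyloxy on a carbonyl carbon. Among the compounds with values here, no measured pair shows this exact exchange, so the step from compound 2 to compound 3, which installs the same carbamoyl group by a different route and stays within the scatter, is the nearest guide; it suggests no large move in this assay. Compound 4 is therefore expected to sit close to compound 1, with a step of a number 4.4 percentage points higher from compound 1 to compound 4 (within the scatter) estimated as at most a modest gain. The estimate for compound 4 is 20%, within a range of 8% to 36%.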

Compound 4, a percentage reported as activity, at one dose (the size of the read-out at that dose, not a potency): 32.3%
Compound 4: middle estimate off by 12.3 percentage points, on the low side, and the stated range covers the measured number.
By their numbers in this assay, from the lowest: compound 1; then compounds 2, 4 and 3 (each within the scatter of the next).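

In this assay, going by these compounds alone, amino in place of benzyloxy on a carbonyl carbon gives a number 16.7 percentage points higher from compound 1 to compound 4 (beyond the scatter) and so provides the first single change in this set that lies beyond the scatter, while a number 2.8 percentage points higher from compound 2 to compound 3 (within the scatter) stayed within it. At this position, then, the exchange of benzyloxycarbonyl for carbamoyl raises the read-out at the dose given, and the six-membered aromatic ring of the benzyloxy group is not needed to reach that level. Nothing available here accounts for this rise.

As far as these compounds go, it remains open whether a carboxylic acid or a dimethylamino group on the same carbonyl carbon would give a similar read-out, and whether a longer chain carrying the carbamoyl group would keep it. From the compounds shown here alone, it is also open whether the step would persist at other doses and times.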